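This account rests on a few compounds, and the source may have more. Where it says the series, first, only, none or still open, it means among the compounds named here.

Of the compounds shown here, three sharing one core have been measured in a functional assay on L6 cells (Rattus norvegicus) for inhibition; a higher number here means a weaker inhibitor, a lower number a stronger inhibitor. Compound 1, `CC(C)c1c(C(=O)N2CCCC2c2ccccc2)nn(-c2ccc(F)cc2)c1OC[C@@H](O)C[C@@H](O)CC(=O)O`, gives 4340 nM in this assay. Compound 2, `CC(C)c1c(C(=O)N2CCC[C@H](c3ccccc3)C2)nn(-c2ccc(F)cc2)c1OC[C@@H](O)C[C@@H](O)CC(=O)O`, gives 1110 nM, the lowest of the three numbers: compound 3 sits a 3.2-fold higher number from compound 2 to compound 3 (0.51 log units; beyond the scatter), and compound 1 sits furthest, the step being a 3.9-fold lower number from compound 1 to compound 2 (0.59 log units; beyond the scatter) in the other direction. Compound 3, `COCc1cccc(CNC(=O)c2nn(-c3ccc(F)cc3)c(OC[C@@H](O)C[C@@H](O)CC(=O)O)c2C(C)C)c1`, gives 3600 nM.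

The next compound, compound 4, is `COc1cccc(CN(C)C(=O)c2nn(-c3ccc(F)cc3)c(OC[C@@H](O)C[C@@H](O)CC(=O)O)c2C(C)C)c1`. It differs from compound 2 in one place: (3-methoxybenzyl)(methyl)amino in place of 3-phenylpiperidin-1-yl on a carbonyl carbon.

Among the compounds with values here, the step that bears most on this change is the one from compound 2 to compound 3, where a benzyl-type amine also took the place of the 3-phenylpiperidin-1-yl group and the number rose a 3.2-fold higher number from compound 2 to compound 3 (0.51 log units; beyond the scatter). The entering group in compound 4 is a close relative of that in compound 3, so a similar, modest rise in this assay is expected, giving a 2.7-fold higher number from compound 2 to compound 4 (0.43 log units; beyond the scatter). Compound 4 is therefore estimated at 3000 nM, with a likely range from 1200 nM to 8000 nM.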

Compound 4, half-maximal inhibitory concentration: 9460 nM
For compound 4 the middle estimate is 3.2-fold (0.50 log units) below the measured one, and the stated range ends below it.
By their numbers in this assay, from the lowest: compound 2; then compounds 3 and 1 (each within the scatter of the next); then compound 4.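

In this assay, compound 4 is the weakest of the four inhibitors, with an 8.5-fold higher number from compound 2 to compound 4 (0.93 log units; beyond the scatter), a 2.6-fold higher number from compound 3 to compound 4 (0.42 log units; beyond the scatter) and a 2.2-fold higher number from compound 1 to compound 4 (0.34 log units; beyond the scatter). Compound 4 and compound 3 both carry a substituted benzyl group on the amide nitrogen, yet they are not equivalent at this carbonyl carbon, so a broad resemblance between groups is a poor guide here. Nothing shown accounts for this loss of inhibition.

On these data alone, compound 4 differs from compound 3 both in having a methyl on the amide nitrogen in place of the amide hydrogen and in its ring substituent, methoxy rather than methoxymethyl, so the contribution of each remains open. The (3-methoxybenzyl)amino group, which keeps the amide hydrogen and the methoxy, would help separate the two.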